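Third methoxy on the aryl at the carbonyl carbon

The source may report more compounds than this note shows. Statements on the series, on what has been measured and on what is new or still open speak of the compounds shown alone.

Measured in a functional assay on SNB-19 cells (Homo sapiens) for cytotoxicity, read by sulforhodamine B assay, with a stated time of 48 h, tested at 0.01 uM; on this read-out lower numbers stand for a stronger effect and higher numbers for a weaker effect at the one concentration tested:
compound 1 `COc1cc(-c2cc(/C=C/C(=O)c3ccc(Cl)c(Cl)c3)[nH]n2)cc(OC)c1OC`: 100%
compound 2 `COc1ccc(-c2cc(/C=C/C(=O)c3cc(OC)c(OC)c(OC)c3)[nH]n2)cc1OC`: 91%
compound 3 `COc1ccc(C(=O)/C=C/c2cc(-c3cc(OC)c(OC)c(OC)c3)n[nH]2)cc1OC`: 91%

Compound 3 reads level with compound 2 at the digits given; the two share the lowest number of the three. Within the data shown here, compound 1 lies higher, and the only single-point step measured runs a number 9 percentage points lower from compound 1 to compound 3 (within the scatter), a change on the aryl at the carbonyl carbon that stays inside the scatter.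

Compound 4 `COc1cc(C(=O)/C=C/c2cc(-c3cc(OC)c(OC)c(OC)c3)n[nH]2)cc(OC)c1OC` is not yet measured. Relative to compound 3 it carries methoxy in place of hydrogen on an aromatic carbon. Among the measured compounds shown here, no measured step adds a methoxy; the one step that alters this aryl stayed within the scatter, so no movement beyond the scatter is expected in this assay, and the step from compound 3 is estimated at no change at the digits printed from compound 3 to compound 4 (within the scatter). Compound 4 is expected near 91%, within 80% to 100%.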

Compound 4, a percentage reported as activity, at one concentration (the size of the read-out at that concentration, not a potency): 92%
For compound 4 the middle estimate is 1 percentage points below the measured one; low and high end bracket the measured number.
By their numbers in this assay, from the lowest: compounds 2, 3, 4 and 1 (each within the scatter of the next).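

In this assay methoxy in place of hydrogen gives a number 1 percentage points higher from compound 3 to compound 4 (within the scatter) on the aryl at the carbonyl carbon and a number 1 percentage points higher from compound 2 to compound 4 (within the scatter) on the other aryl. Among these compounds, these are the first measured methoxy additions, and on both aryls the read-out stays within the scatter at the one concentration tested. No evidence on hand bears on this result.

Still open, as far as these compounds go, is whether a different group at this position, such as an amine or a carboxylic acid, would move the read-out beyond the scatter. From the compounds shown here alone, whether these compounds would separate at higher concentrations also remains unknown.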